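Benzyl substitution: from compound 2 to compound 3

The source may hold more compounds than are shown below. What is called first, only, known or untested is meant among the compounds shown, and "the series" means these compounds.

Measured so far in a functional assay on aorta (Rattus norvegicus, strain Sprague-Dawley); on this read-out higher numbers stand for an effect only at larger amounts of compound and lower numbers for an effect already at smaller amounts:
- compound 1 `Cc1cccc(COc2nc3c(cc2-c2nc(N)cc(N)n2)c(C)nn3-c2ccccc2)c1` gives 990 nM
- compound 2 `Cc1nn(-c2ccccc2)c2nc(OCc3ccccc3)c(-c3nc(N)cc(N)n3)cc12` gives 10800 nM

Compound 2 stands highest of the two numbers, so its effect appears only at the larger amount. Compound 3 `Cc1nn(-c2ccccc2)c2nc(OCc3ccc(C(F)(F)F)cc3)c(-c3nc(N)cc(N)n3)cc12` carries trifluoromethyl in place of hydrogen on an aromatic carbon of the benzyl group, para to a large group (trifluoromethyl in place of hydrogen on an aromatic carbon). Among the measured compounds shown here, one measured step bears on this change: an 11-fold higher number from compound 1 to compound 2 (1.04 log units; beyond the scatter), a large step beyond the scatter, with hydrogen replacing methyl on the benzyl group. Read backwards, that step links a group on the benzyl to a lower number. However, methyl is not trifluoromethyl and one step sets no rule, so a smaller move towards a lower number is expected in this assay. The expected change is a 3.6-fold lower number from compound 2 to compound 3 (0.56 log units; beyond the scatter), within a wide range. For compound 3 the estimated value is 3000 nM (range 500 nM to 13000 nM).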

Compound 3, half-maximal effective concentration: 1600 nM
Estimate against measurement, compound 3: 1.9-fold (0.27 log units) above; the range from low to high includes it.
By their numbers in this assay, from the lowest: compounds 1 and 3 (each within the scatter of the next); then compound 2.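

In this assay, a substituent on the benzyl group again matters: trifluoromethyl on the aromatic carbon para to a large group gives a 6.8-fold lower number from compound 2 to compound 3 (0.83 log units; beyond the scatter), so the earlier effect of methyl is not unique to that group or its place on the ring. Exchanging 3-methylphenyl for 4-(trifluoromethyl)phenyl gives a 1.6-fold higher number from compound 1 to compound 3 (0.21 log units; within the scatter), so the two substituted benzyl groups cannot be told apart here, while the unsubstituted benzyl of compound 2 stands apart from both. No supporting measurement on hand accounts for these shifts.

Because methyl and trifluoromethyl occupy different places on the ring, the compounds shown do not separate the identity of the group from its placement. Going by these compounds, whether an amine or a carboxylic acid on the same aromatic carbon would also give a lower number remains open.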